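This account rests on a few compounds, and the source may have more. Where it says the series, first, only, none or still open, it means among the compounds named here.

Measured compounds:
- compound 1, `Cc1ccc(-n2nccn2)c(C(=O)N2C[C@H](C#Cc3cnccc3O)CC[C@H]2C)c1`: 3880 nM
- compound 2, `Cc1ccc(-n2nccn2)c(C(=O)N2C[C@H](C#Cc3cccnc3O)CC[C@H]2C)c1`: "not determined" (no result reported)

The study concerns the triple-bonded side arm of a shared core. In a functional assay on isolated protein for antagonist activity at Orexin/Hypocretin receptor type 1 (Homo sapiens), read by FLIPR and calcium flux (on this read-out higher numbers stand for weaker inhibition and lower numbers for stronger inhibition), compound 1 gives 3880 nM, a weak inhibition on this scale. Compound 2, which carries the 2-hydroxypyridin-3-yl group on the triple-bonded carbon, stands nowhere on the numbers shown: in this assay compound 2 gives "not determined" (no result reported), so its position relative to compound 1 stays open.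

Compound 3, `Cc1ccc(-n2nccn2)c(C(=O)N2C[C@H](C#Cc3ccc(F)cn3)CC[C@H]2C)c1`, is the compound still to be measured. It differs from compound 2 in one place: 5-fluoropyridin-2-yl in place of 2-hydroxypyridin-3-yl on a triple-bonded carbon. Among the measured compounds shown here, no step between measured compounds describes this kind of exchange, and compound 2 itself has no number, so the size and direction of the move from compound 2 to compound 3 cannot be read from the data. Taking compound 1 as the only anchor, the expectation is a shift in this assay toward stronger inhibition, of a size that may well exceed the usual scatter, but with wide uncertainty. Compound 3 is estimated at 800 nM, with a likely range of 120 nM to 5000 nM.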

Compound 3, half-maximal inhibitory concentration: 31 nM
The estimate for compound 3 lay 26-fold (1.41 log units) above the measured number; measured number outside the range, below it.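

In this assay, the side arm on the triple-bonded carbon turns out to tolerate a large change: exchanging 4-hydroxypyridin-3-yl for 5-fluoropyridin-2-yl gives a 130-fold lower number from compound 1 to compound 3 (2.10 log units; beyond the scatter), so compound 3 shows that this position can carry a step well beyond the scatter on the shared core. The exchange swaps one whole ring group for another, with the hydroxyl leaving and the fluorine entering in a single step, and the two compounds alone do not divide the step between these changes. Nothing on hand bears on why the number fell so far.

On these data alone, compound 2 has no number, so the step from it to compound 3 cannot be read, and the standing of 2-hydroxypyridin-3-yl on this arm stays open. Also open, as far as these compounds go, is how the read-out would respond to an unsubstituted pyridin-2-yl, a plain phenyl or a 5-chloropyridin-2-yl on the same triple-bonded carbon, any of which would help separate the contribution of the fluorine from that of the ring itself.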